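Compound 4 in the triazole aryl series: nitro for acetyl

A few compounds are considered here, and "the series" means these few. Any claim that something is new, unique, unknown or untested is made for them only; others in the source may bear on it.

Values in a functional assay on B16 cells (Mus musculus) for cytotoxicity, read by MTT assay, with a stated time of 48 h; a lower number here means a stronger inhibitor, a higher number a weaker inhibitor:
Compound 1 `C=C1CCC[C@]2(C)CCC(C=O)=CC[C@@]12C`: 230000 nM
Compound 2 `C=C1CCC[C@]2(C)CCC(c3cn(-c4ccc(OC)cc4)nn3)=CC[C@@]12C`: 209000 nM
Compound 3 `C=C1CCC[C@]2(C)CCC(c3cn(-c4ccc(C(C)=O)cc4)nn3)=CC[C@@]12C`: 61000 nM
Compound 4 `C=C1CCC[C@]2(C)CCC(c3cn(-c4cccc([N+](=O)[O-])c4)nn3)=CC[C@@]12C`: not yet measured

Compound 3 holds the lowest of the three numbers in this assay, and both other compounds lie beyond the scatter from it. The next change is 3-nitrophenyl in place of 4-acetylphenyl on an aromatic nitrogen. Among the measured compounds shown here, only one measured step bears on this group: a 3.4-fold lower number from compound 2 to compound 3 (0.53 log units; beyond the scatter), with acetyl in place of methoxy on an aromatic carbon. For the measured compounds named here, that step is modest, and no measured compound carries 3-nitrophenyl, so it gives a scale for the change but no firm direction. A small move towards a higher number is expected, most likely not beyond the scatter, and a change on the scale of the measured step remains possible in either direction. The expected change is a 1.5-fold higher number from compound 3 to compound 4 (0.17 log units; within the scatter). Compound 4 is estimated at 90000 nM, with an expected range of 40000 nM to 200000 nM.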

Compound 4, half-maximal inhibitory concentration: 31700 nM
The estimate for compound 4 lay 2.8-fold (0.45 log units) above the measured number, outside the stated range (below it).
By their numbers in this assay, from the lowest: compounds 4 and 3 (each within the scatter of the next); then compounds 2 and 1 (each within the scatter of the next).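

In this assay, the step from 4-acetylphenyl to 3-nitrophenyl on the aromatic nitrogen gives a 1.9-fold lower number from compound 3 to compound 4 (0.28 log units; within the scatter) and so separates neither group from the other. Against 4-methoxyphenyl, the same position shows a 6.6-fold lower number from compound 2 to compound 4 (0.82 log units; beyond the scatter) in a comparison that stands clear of the scatter, so a second group joins 4-acetylphenyl apart from 4-methoxyphenyl, and the difference seen earlier no longer rests on a single pair. No measured evidence on these compounds accounts for this.

The aryl groups in compound 3 and compound 4 differ in both substituent and ring location, so the effect of each remains unseparated. A plain phenyl, a 4-nitrophenyl or a 3-aminophenyl on the same nitrogen would show whether the substituent itself or its location carries the difference.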